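The source may hold more compounds than are shown below. What is called first, only, known or untested is meant among the compounds shown, and "the series" means these compounds.

For the measured compounds named here, compound 3 `CC[C@H](C)[C@H](NC(=O)CN(c1ncnc2c1ncn2C1CCCCO1)C1CC1)C(=O)OCc1ccccc1` is one of three compounds so far tested in a functional assay on the whole organism (Tail, strain ICR) with Mus musculus as the target, in the tail flick test, with a stated time of 90 min, at a dose of 25 umol/kg by the oral route (on this read-out lower numbers stand for a weaker effect and higher numbers for a stronger effect at the one dose given), where compound 3 gives 22.6%. On paper that is the smallest of the three numbers, but the nearest neighbour, compound 2 `O=C(CN(c1ncnc2c1ncn2C1CCCCO1)C1CC1)NCC(=O)OCc1ccccc1`, gives 25.9% in this assay, and the gap between the two lies within the scatter, so they cannot be told apart. Compound 1 `C[C@H](NC(=O)CN(c1nc(Cl)nc2[nH]cnc12)C1CC1)C(=O)OCc1ccccc1`, which carries a different core, gives 44.2% in this assay, a gap to compound 3 that lies beyond the scatter.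

Compound 4 `NC(=O)C[C@H](NC(=O)CN(c1ncnc2c1ncn2C1CCCCO1)C1CC1)C(=O)OCc1ccccc1` is compound 3 with one change: carbamoylmethyl in place of sec-butyl on a saturated chain carbon bound to an amide-type nitrogen and a carbonyl carbon. Going by the values given here, only one measured step touches the same place. Going from compound 2 to compound 3 put sec-butyl in place of hydrogen on that carbon, and in this assay that step was a number 3.3 percentage points lower from compound 2 to compound 3 (within the scatter). A sizeable change at this carbon therefore left the read-out essentially unmoved. On that evidence the swap to carbamoylmethyl is expected to give no step beyond the scatter, in either direction.

The expected step in this assay is a number 2.4 percentage points higher from compound 3 to compound 4 (within the scatter). Compound 4 is therefore estimated to give 25% in this assay, within a range from 12% to 40%.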

Compound 4, a percentage reported as activity, at one dose (the size of the read-out at that dose, not a potency): 35%
Estimate against measurement, compound 4: 10 percentage points below, within the range that was stated.
By their numbers in this assay, from the lowest: compounds 3, 2, 4 and 1 (each within the scatter of the next, the first and the last beyond it).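

For the compounds shown here, at this carbon the side chain does matter in this assay, since the swap of sec-butyl for carbamoylmethyl gives a number 12.4 percentage points higher from compound 3 to compound 4 (beyond the scatter), the first step at this position to exceed the usual scatter. The comparison with hydrogen tempers that finding: the new step, a number 9.1 percentage points higher from compound 2 to compound 4 (within the scatter), stays within the scatter, as did the earlier a number 3.3 percentage points lower from compound 2 to compound 3 (within the scatter), so neither group can be told apart from hydrogen and only the two groups differ from each other. Both have the same number of heavy atoms, but carbamoylmethyl brings a nitrogen, an oxygen, a hydrogen-bond donor and a hydrogen-bond acceptor, and no measurement shown here connects any of these features to the step.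

The compounds shown leave open whether a carboxylic acid, an amine or a longer carbon chain at this carbon would move the number clearly away from that of compound 2, and whether a simple amide is needed at all. They also leave open whether the step between sec-butyl and carbamoylmethyl would look the same on the core of compound 1.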